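The source may hold more compounds than are shown below. What is called first, only, known or untested is meant among the compounds shown, and "the series" means these compounds.

Compound 1 `CC1=C(CC(=O)N(C)CCN(C)C(=O)[C@@H](N)C(C)C)c2cc(F)ccc2/C1=C\c1ccc([S+](C)[O-])cc1`: > 50000 nM
Compound 2 `CC1=C(CC(=O)N(C)CCN(C)S(C)(=O)=O)c2cc(F)ccc2/C1=C\c1ccc([S+](C)[O-])cc1`: 12500 nM

Both compounds were tested in a functional assay on MDA-MB-231 cells (Homo sapiens) for inhibition, read by CellTiter-Glo, with a stated time of 72 h; on this read-out lower numbers stand for higher toxicity in this test and higher numbers for lower toxicity in this test. For compound 1, > 50000 nM is a limit of the assay and not a number. Among the measured compounds shown here, compound 2, at 12500 nM, therefore holds the only true number so far. For the measured compounds named here, the one measured step, an at least 4.0-fold lower number from compound 1 to compound 2 (0.60 log units; beyond the scatter), put methylsulfonyl in place of (1-amino-2-methylpropyl)carbonyl on an amine nitrogen, and it starts from the limit of > 50000 nM in this assay, at which 1 of the 2 values shown sits.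

Compound 3 `CC1=C(CC(=O)N(C)CCN(C)S(=O)(=O)c2ccccc2)c2cc(F)ccc2/C1=C\c1ccc([S+](C)[O-])cc1` differs from compound 2 by phenyl in place of methyl on a sulfonyl sulfur. Going by the values given here, no measured step changes this group, so the earlier step is only a loose guide. With compound 2 at 12500 nM as the anchor, only a small move towards lower numbers seems likely, probably within the scatter. The expected step is a 1.4-fold lower number from compound 2 to compound 3 (0.14 log units; within the scatter). In this assay, the estimated value for compound 3 is 9000 nM, with an expected range of 3000 nM to 30000 nM.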

Compound 3, half-maximal cytotoxic concentration: 12200 nM
Compound 3: middle estimate off by 1.4-fold (0.13 log units), on the low side; the measured number falls inside the stated range.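

On the sulfonyl sulfur, phenyl brings in a whole six-membered aromatic ring where methyl stood, yet this assay shows a 1.0-fold lower number from compound 2 to compound 3 (0.01 log units; within the scatter), so the two compounds cannot be told apart in this test. Replacing the (1-amino-2-methylpropyl)carbonyl group with phenylsulfonyl gives an at least 4.0-fold lower number from compound 1 to compound 3 (0.61 log units; beyond the scatter), so the step seen earlier with methylsulfonyl is now seen with a second sulfonyl group. The true size of this step stays unknown, as the value of compound 1 is a limit and not a number: the limit of > 50000 nM in this assay, at which 1 of the 3 values shown sits.

As far as these compounds go, it remains open whether a longer chain such as butyl, or a phenyl carrying a chlorine or a methoxy group, on the sulfonyl sulfur would separate from these two values. From the compounds shown here alone, it is also open whether a plain acetyl group on the amine nitrogen would sit with the sulfonyl compounds or nearer compound 1.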